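This account rests on a few compounds, and the source may have more. Where it says the series, first, only, none or still open, it means among the compounds named here.

In an ADME assay on cells (Epithelial cell, Homo sapiens) for antiproliferative activity, read by MTT assay, with a stated time of 48 h (a lower number here means a stronger inhibitor, a higher number a weaker inhibitor), compound 1 (`COC(=O)/C(=C/c1ccccc1)CN1C(=O)[C@@H](OC)[C@H]1c1ccc(Cl)cc1Cl`) gives 70000 nM. Within the data shown here, compound 2 (`CCOC(=O)/C(=C/c1ccccc1)CN1C(=O)[C@@H](OC)[C@H]1c1ccccc1Br`) gives 66600 nM, and these two numbers lie within the scatter of each other, so compound 1 stands level with the only other measured compound. Compound 3 (`COC(=O)/C(=C/c1ccccc1)CN1C(=O)[C@@H](OC)[C@H]1c1cccc(C(F)(F)F)c1`) keeps the core of compound 1 but carries 3-(trifluoromethyl)phenyl in place of 2,4-dichlorophenyl on a saturated ring carbon. Among the measured compounds shown here, no two measured compounds differ in one place only, so the data do not show what a swap of this kind does in this assay. For the measured compounds named here, the only guide is that compound 1 at 70000 nM and compound 2 at 66600 nM sit close together, so no change beyond the scatter is expected, and no direction is firm. The expected step is a 1.3-fold lower number from compound 1 to compound 3 (0.10 log units; within the scatter). The estimate for compound 3 is 55000 nM, with an expected range from 18000 nM to 120000 nM.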

Compound 3, half-maximal inhibitory concentration: 71800 nM
The estimate for compound 3 lay 1.3-fold (0.12 log units) below the measured number; low and high end bracket the measured number.
By their numbers in this assay, from the lowest: compounds 2, 1 and 3 (each within the scatter of the next).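

In this assay, among these compounds, compound 1 and compound 3 form the first pair that differs in one place only, and 3-(trifluoromethyl)phenyl in place of 2,4-dichlorophenyl on the saturated ring carbon gives a 1.0-fold higher number from compound 1 to compound 3 (0.01 log units; within the scatter) in this comparison. At this position, then, these two differently substituted phenyl groups cannot be told apart by this read-out, even though they differ in both the kind and the placing of their substituents. No measurement shown explains why the two groups read alike.

As far as these compounds go, both groups carry halogen atoms, so it remains open whether a phenyl ring bearing an amine or a carboxylic acid, or a butyl chain in place of the ring, would give a number beyond the scatter. Also open, from the compounds shown here alone, is whether a hydroxyl group in place of the methoxy group would do so.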